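Cytotoxicity in the series: removing the pyridin-2-yl ether

The source may report more compounds than this note shows. Statements on the series, on what has been measured and on what is new or still open speak of the compounds shown alone.

Compound 1 `CC(C)(C)C#Cc1cc(N(C(=O)[C@H]2CC[C@H](C)CC2)[C@H]2CC[C@H](Oc3ccccn3)CC2)c(C(=O)O)s1` carries a pyridin-2-yl ether on the cyclohexyl ring. In an ADME assay on MT4 cells (Homo sapiens) for cytotoxicity, with a stated time of 5 days (on this read-out higher numbers stand for lower toxicity in this test and lower numbers for higher toxicity in this test), compound 1 gives only a limit, > 20000 nM. Compound 2 `CC(C)(C)C#Cc1cc(N(C(=O)[C@H]2CC[C@H](C)CC2)[C@H]2CC[C@@H](Oc3ccc(=O)[nH]n3)CC2)c(C(=O)O)s1` also gives only a limit in this assay, > 20000 nM. Compound 3 `CC(C)(C)C#Cc1cc(N(C(=O)[C@H]2CC[C@H](C)CC2)[C@H]2CC[C@@H](Oc3cccnc3)CC2)c(C(=O)O)s1` likewise gives only a limit, > 20000 nM. Within the data shown here, the one step measured between neighbours, a step that the two limits leave unreadable from compound 2 to compound 3, cannot be read for size, as the limit of > 20000 nM in this assay, at which 3 of the 3 values shown sit, shows; every value shown sits at that limit.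

Compound 4 `CC(C)(C)C#Cc1cc(N(C(=O)[C@H]2CC[C@H](C)CC2)[C@H]2CC[C@H](O)CC2)c(C(=O)O)s1` differs from compound 1 by hydrogen in place of pyridin-2-yl on an oxygen on a saturated carbon. Among the measured compounds shown here, no measured step speaks to this change directly, and the one measured step is itself unreadable, so no step beyond the scatter can be expected in this assay in either direction; the expectation is that compound 4 stays at the limit. Compound 4 is therefore estimated at 30000 nM in this assay, with a range from 12000 nM to 80000 nM. The step this estimate implies, a step that the limit leaves unreadable from compound 1 to compound 4, is expected to be none beyond the scatter.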

Compound 4, half-maximal cytotoxic concentration: > 20000 nM
Compound 4 ended at the assay's limit; the forecaster's own chance of this, stated with the estimate: 85%; the middle value does not contradict the limit.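

No new step can be read between compound 1 and compound 4, because both values are limits, not numbers: the limit of > 20000 nM in this assay, at which 4 of the 4 values shown sit.

Going by these compounds, whether hydrogen in place of pyridin-2-yl changes cytotoxicity in this assay stays open, as does any order among compound 1, compound 2, compound 3 and compound 4.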